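Swapping 3,5-dimethoxyphenyl for 3,5-dichlorophenyl: compound 3 to compound 4

The source may hold more compounds than are shown below. What is called first, only, known or untested is meant among the compounds shown, and "the series" means these compounds.

- compound 1 `COc1cc(OC)c(C(=O)/C=C/c2ccc(Br)cc2)c(OCC=C(C)C)c1` gives 2100 nM
- compound 2 `COc1cc(OC)c(C(=O)/C=C/c2cccc(Cl)c2Cl)c(OCC=C(C)C)c1` gives 1900 nM
- compound 3 `COc1cc(/C=C/C(=O)c2c(OC)cc(OC)cc2OCC=C(C)C)cc(OC)c1` gives 3500 nM

In a functional assay on HCT-116 cells (Homo sapiens) for antiproliferative activity, read by sulforhodamine B assay, with a stated time of 48 h (on this read-out lower numbers stand for stronger inhibition and higher numbers for weaker inhibition), compound 3 gives 3500 nM and cannot be ranked against the other two. The steps that reach it, a 1.7-fold higher number from compound 1 to compound 3 (0.22 log units; within the scatter) and a 1.8-fold higher number from compound 2 to compound 3 (0.27 log units; within the scatter), both stay within the scatter.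

Compound 4 `COc1cc(OC)c(C(=O)/C=C/c2cc(Cl)cc(Cl)c2)c(OCC=C(C)C)c1` differs from compound 3 in one place, by 3,5-dichlorophenyl in place of 3,5-dimethoxyphenyl on a double-bonded chain carbon bound to a double-bonded chain carbon on a double-bonded chain carbon bound to a double-bonded chain carbon, with 3,5-dichlorophenyl in place of 3,5-dimethoxyphenyl. The measured steps at this same place all bear on it. The closest is a 1.8-fold higher number from compound 2 to compound 3 (0.27 log units; within the scatter), which joins a dichlorophenyl compound to compound 3, and a 1.1-fold lower number from compound 1 to compound 2 (0.04 log units; within the scatter) is equally small. No step beyond the scatter is therefore expected in this assay, and compound 4 is expected to lie near compound 2 at 1900 nM and not far from the others. The expected size of the change is a 1.6-fold lower number from compound 3 to compound 4 (0.20 log units; within the scatter) and nothing larger is foreseen. Compound 4 is estimated at 2200 nM with a range from 1100 nM to 4500 nM as its expected bounds.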

Compound 4, half-maximal inhibitory concentration: 24500 nM
The estimate for compound 4 lay 11-fold (1.05 log units) below the measured number; measured number above the stated range.
By their numbers in this assay, from the lowest: compounds 2, 1 and 3 (each within the scatter of the next); then compound 4.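

In this assay the group at this place, on a double-bonded chain carbon bound to a double-bonded chain carbon, proves able to move the number: the step of a 7.0-fold higher number from compound 3 to compound 4 (0.85 log units; beyond the scatter) lies beyond the scatter, as do a 13-fold higher number from compound 2 to compound 4 (1.11 log units; beyond the scatter) and a 12-fold higher number from compound 1 to compound 4 (1.07 log units; beyond the scatter) while the steps among compound 1, compound 2 and compound 3 all stayed within it. The step from compound 2 is the telling one, since 2,3-dichlorophenyl and 3,5-dichlorophenyl are both dichlorophenyl groups, so the presence of chlorine on this ring does not by itself set the number. Nothing measured here offers an explanation for this separation.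

On these data alone, whether 3,5-dibromophenyl or 3,5-dimethylphenyl would side with compound 4 remains open. So does the outcome of an amine or a carboxylic acid on this ring.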